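This account rests on a few compounds, and the source may have more. Where it says the series, first, only, none or still open, it means among the compounds named here.

Working notes on the series.

The three measured compounds share one core and differ only in the aryl group on the nitrogen on the aromatic ring. In an assay on isolated protein for inhibition of leukotriene C4 synthase (Homo sapiens), read by LC-MS, with stated times of 45 min and 20 min (a higher number here means a weaker inhibitor, a lower number a stronger inhibitor), compound 1 `COc1cc(N(CC2CC2)c2ccc(Cl)c(Cl)c2)cnc1C(=O)[C@H]1C[C@@H]1C(=O)O` gives 27.7 nM. Compound 2 `COc1cc(N(CC2CC2)c2ccccc2)cnc1C(=O)[C@H]1C[C@@H]1C(=O)O` gives 1640 nM in this assay, and compound 3 `COc1cc(N(CC2CC2)c2cc(Cl)ccc2F)cnc1C(=O)[C@H]1C[C@@H]1C(=O)O` gives 34.3 nM. Compound 3 thus stands second highest of the three numbers; its nearest neighbour is compound 1, with a 1.2-fold higher number from compound 1 to compound 3 (0.09 log units; within the scatter), a step within the scatter, while its furthest is compound 2, with a 48-fold lower number from compound 2 to compound 3 (1.68 log units; beyond the scatter).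

Compound 4 `COc1cc(N(CC2CC2)c2ccc(F)c(Cl)c2)cnc1C(=O)[C@H]1C[C@@H]1C(=O)O` is the next member, not yet measured. The change from compound 3 is 3-chloro-4-fluorophenyl in place of 5-chloro-2-fluorophenyl on a nitrogen on an aromatic ring. Going by the values given here, two measured steps bear on it. The step of a 1.2-fold higher number from compound 1 to compound 3 (0.09 log units; within the scatter) shows that exchanging one chloro-fluoro-phenyl pattern for a dichloro pattern left the number essentially unchanged. The steps of a 59-fold higher number from compound 1 to compound 2 (1.77 log units; beyond the scatter) and a 48-fold lower number from compound 2 to compound 3 (1.68 log units; beyond the scatter) show that only the loss of both halogens moved the number far. Compound 4 keeps two halogens, so the expected step of a 1.0-fold higher number from compound 3 to compound 4 (0.01 log units; within the scatter) lies within the scatter. For compound 4 the estimate in this assay is 35 nM, with a range from 12 nM to 100 nM.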

Compound 4, half-maximal inhibitory concentration: 42.3 nM
Compound 4: the middle estimate sits 1.2-fold (0.08 log units) below what was measured; measured number inside the range.
By their numbers in this assay, from the lowest: compounds 1, 3 and 4 (each within the scatter of the next); then compound 2.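

In this assay, going by these compounds alone, 3-chloro-4-fluorophenyl in place of 5-chloro-2-fluorophenyl on the nitrogen gives a 1.2-fold higher number from compound 3 to compound 4 (0.09 log units; within the scatter), so rearranging the same atoms does not separate this pair, which is the first comparison of two isomeric aryl groups. The exchange of a single halogen, fluoro in place of chloro on an aromatic carbon, gives a 1.5-fold higher number from compound 1 to compound 4 (0.18 log units; within the scatter), which also does not separate the pair, whereas 3-chloro-4-fluorophenyl in place of phenyl gives a 39-fold lower number from compound 2 to compound 4 (1.59 log units; beyond the scatter), so all three halogen-bearing aryl groups now stand far from the bare phenyl of compound 2. No independent data are available here to explain these readings at this position.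

The compounds shown leave open how a phenyl bearing chloro alone or fluoro alone would read, and so whether one halogen is enough to account for the large steps from compound 2. They also leave open whether a trifluoromethyl, methoxy or nitrile group on that phenyl would stand with the halogenated compounds or with compound 2.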